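Terminal aryl variation: expectation for compound 3

The source may hold more compounds than are shown below. What is called first, only, known or untested is meant among the compounds shown, and "the series" means these compounds.

Measured in a functional assay on SF-268 cells (Homo sapiens) for inhibition, read by sulforhodamine B assay, with a stated time of 48 h; on this read-out lower numbers stand for stronger inhibition of growth and higher numbers for weaker inhibition of growth:
compound 1 `COc1cc(-c2nn(-c3cccc(NC(=O)Nc4ccc(Cl)c(Cl)c4)c3)cc2-c2ccncc2)ccc1Cl`: 1510 nM
compound 2 `COc1cc(-c2nn(-c3cccc(NC(=O)Nc4cccc(C(F)(F)F)c4)c3)cc2-c2ccncc2)ccc1Cl`: 1360 nM

Compound 2 and compound 1 differ only in the aryl on the amide-type nitrogen, and their numbers lie within the scatter of each other: a 1.1-fold lower number from compound 1 to compound 2 (0.05 log units; within the scatter). On the two numbers at hand compound 2 therefore has no separate standing; it and compound 1 read as one level in this assay.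

Compound 3 `COc1cc(-c2nn(-c3cccc(NC(=O)Nc4ccc(Cl)c(C(F)(F)F)c4)c3)cc2-c2ccncc2)ccc1Cl` is not yet measured. Compared with compound 2 the change is chloro in place of hydrogen on an aromatic carbon; the same difference, cut one bond further out, reads 3-(trifluoromethyl)phenyl to 4-chloro-3-(trifluoromethyl)phenyl.

Among the measured compounds shown here, the only measured step, from compound 1 to compound 2, exchanged the whole aryl and moved the number by less than the scatter. Compound 1 already carries a chloro at the same place on its aryl as compound 3 will, and compound 1 and compound 2 give near-identical numbers. For the measured compounds named here, no measured step speaks for a shift beyond the scatter, so the step expected is a 1.0-fold lower number from compound 2 to compound 3 (0.02 log units; within the scatter). Compound 3 is accordingly estimated at 1300 nM, within 600 nM to 2800 nM.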

Compound 3, concentration for 50% growth inhibition: 1460 nM
Compound 3: middle estimate off by 1.1-fold (0.05 log units), on the low side, within the range that was stated.
By their numbers in this assay, from the lowest: compounds 2, 3 and 1 (each within the scatter of the next).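

In this assay, chloro in place of hydrogen, on the aromatic carbon ortho to a trifluoromethyl group and para to a large group, leaves the two compounds at one level: a 1.1-fold higher number from compound 2 to compound 3 (0.03 log units; within the scatter). Compound 3 also separates the earlier exchange of the whole aryl into single changes, and the second of these, trifluoromethyl in place of chloro on an aromatic carbon, likewise stays at that level: a 1.0-fold lower number from compound 1 to compound 3 (0.01 log units; within the scatter). Neither change, taken alone, shifts the number beyond the scatter, so the three compounds now read as one level, with none going against this; no evidence bearing on this result is at hand.

As far as these compounds go, the terminal aryl in these compounds carries only hydrogen, chloro or trifluoromethyl at the places varied, so it remains open whether an amine or a carboxylic acid there would leave the number at the same level. From the compounds shown here alone, it also remains open whether this level holds when the shared core is changed, for instance when the methoxy group gives way to a longer chain.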